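Nitro for Methyl on a Dopamine Transporter Scaffold

A few compounds are considered here, and "the series" means these few. Any claim that something is new, unique, unknown or untested is made for them only; others in the source may bear on it.

Measured compounds:
compound 1 `Cc1ccc(C(O)CCN2CC=C(Cc3ccccc3)CC2)cc1`: 30%
compound 2 `OC(CCN1CCC(O)(Cc2ccccc2)CC1)c1csc2ccccc12`: 64%

In an assay on CHO cells for inhibition of sodium-dependent dopamine transporter (Homo sapiens), read by scintillation counting, with a stated time of 10 min, tested at 10 uM (a higher number here means more inhibition at the concentration tested (going by the name of the read-out), a lower number less inhibition), compound 1 gives 30%, the lower of the two numbers shown, while compound 2 gives 64%, a gap that lies beyond the scatter. Compound 3 `O=[N+]([O-])c1ccc(C(O)CCN2CC=C(Cc3ccccc3)CC2)cc1` differs from compound 1 by nitro in place of methyl on an aromatic carbon. Going by the values given here, no measured pair shows this change, so its size is uncertain; a small step in either direction, or none beyond the scatter, is expected: a number 5 percentage points higher from compound 1 to compound 3 (within the scatter). Compound 3 is therefore estimated to give about 35% in this assay, within 10% to 60%.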

Compound 3, a percentage reported as inhibition, at one concentration (the size of the read-out at that concentration, not a potency): 55%
Beside the measured number, compound 3's estimate is 20 percentage points below it; the range from low to high includes it.
By their numbers in this assay, from the lowest: compound 1; then compounds 3 and 2 (each within the scatter of the next).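

Placing nitro instead of methyl on the aromatic carbon para to a large group gives a number 25 percentage points higher from compound 1 to compound 3 (beyond the scatter) in this assay, so this position on the core of compound 1 is not indifferent to the group it carries. Going by these compounds alone, the step is modest, but it is the first measured change at this position. Nothing measured here accounts for it. From the compounds shown here alone, whether an amine, a nitrile or a carboxylic acid at this position would give a similar step remains open, as does the effect of nitro elsewhere on this ring.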